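The source may report more compounds than this note shows. Statements on the series, on what has been measured and on what is new or still open speak of the compounds shown alone.

Compound 1 `O=C(NCc1ccccc1Br)N1C(=O)c2ccccc2S1(=O)=O`: > 166 h
Compound 2 `O=C(NCC1CCCCC1)N1C(=O)c2ccccc2S1(=O)=O`: > 166 h

In a physicochemical assay for pharmacokinetics (on this read-out higher numbers stand for a longer-lived compound and lower numbers for a shorter-lived compound), compound 1 gives > 166 h, which is a limit and not a number. Compound 2 gives > 166 h, also a limit. Compound 1 therefore stands at the limit of > 166 h in this assay, at which 2 of the 2 values shown sit.

Compound 3 `O=C(NCc1ccccc1C(F)(F)F)N1C(=O)c2ccccc2S1(=O)=O` has trifluoromethyl in place of bromo on an aromatic carbon. Among the measured compounds shown here, the only measured step is a step that the two limits leave unreadable from compound 1 to compound 2, and it changes the group on the chain rather than the substituent on the aromatic ring. It offers no size or direction to carry over, so no change beyond the scatter is expected. The expected step is a step that the limit leaves unreadable from compound 1 to compound 3. For compound 3 the estimated half-life in this assay is 200 h, with an expected range from 100 h to 450 h.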

Compound 3, half-life: > 166 h
Compound 3: only a limit was reported; the forecaster's own chance of this, stated with the estimate: 75%; the middle value is on the limit's open side.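

No step can be read from compound 1 to compound 3, since both values are limits: the limit of > 166 h in this assay, at which 3 of the 3 values shown sit.

The compounds shown leave open how long each actually lasts in this assay, and whether swapping bromo for trifluoromethyl changes that at all.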